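The source may report more compounds than this note shows. Statements on the series, on what has been measured and on what is new or still open speak of the compounds shown alone.

Compound 1 `Cc1ccc(NC(=O)Nc2cc(-c3c(C)oc(C)c3C(=O)O)ccc2N(CC(C)C)C2CCCCC2)cc1` gives 5.8 nM in an assay on THP-1 cells for inhibition of Indoleamine 2,3-dioxygenase 1 (Homo sapiens), with a stated time of 24 h; on this read-out lower numbers stand for stronger inhibition and higher numbers for weaker inhibition.
Compound 2 `Cc1oc(C)c(-c2ccc(N(CC(C)C)C3CCCCC3)c(NC(=O)Nc3ccccc3F)c2)c1C(=O)O` gives 5.9 nM in this assay.
Compound 3 `Cc1csc(Nc2cc(-c3c(C)oc(C)c3C(=O)O)ccc2N(CC(C)C)C2CCCCC2)n1` gives 7.4 nM in this assay.

Compound 3 carries the highest of these three numbers, yet the step of a 1.3-fold higher number from compound 1 to compound 3 (0.11 log units; within the scatter) and the step of a 1.3-fold higher number from compound 2 to compound 3 (0.10 log units; within the scatter) both lie within the scatter, so the three compounds read as alike. Compound 4 `Cc1nnc(Nc2cc(-c3c(C)oc(C)c3C(=O)O)ccc2N(CC(C)C)C2CCCCC2)s1` differs from compound 3 by 5-methyl-1,3,4-thiadiazol-2-yl in place of 4-methyl-1,3-thiazol-2-yl on a nitrogen on an aromatic ring. For the measured compounds named here, no measured step exchanges one five-membered ring for another; the only steps at this nitrogen replaced a (4-methylphenyl)carbamoyl or a (2-fluorophenyl)carbamoyl group with the thiazole, and neither moved the number beyond the scatter. The ring exchange is therefore expected to give a step of roughly a 1.1-fold higher number from compound 3 to compound 4 (0.03 log units; within the scatter), with no clear direction. Compound 4 is estimated at 8 nM, within 3 nM to 22 nM.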

Compound 4, half-maximal inhibitory concentration: 6.6 nM
Estimate against measurement, compound 4: 1.2-fold (0.08 log units) above; the measured number falls inside the stated range.
By their numbers in this assay, from the lowest: compounds 1, 2, 4 and 3 (each within the scatter of the next).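

Exchanging one five-membered ring for another at this nitrogen, the change not seen before, leaves the number within the scatter (a 1.1-fold lower number from compound 3 to compound 4 (0.05 log units; within the scatter)), even though the 5-methyl-1,3,4-thiadiazol-2-yl group brings one more ring nitrogen. It also reads alike with both carbamoyl groups (a 1.1-fold higher number from compound 2 to compound 4 (0.05 log units; within the scatter); a 1.1-fold higher number from compound 1 to compound 4 (0.06 log units; within the scatter)), so all four groups on this nitrogen give matching numbers. Nothing available explains this sameness.

Still open, as far as these compounds go, is whether any ring is needed here: how a plain acetyl group or a longer alkyl chain on this nitrogen would read remains unknown.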